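Benzyl purines with chloromethyl arm: amino for chloro

A few compounds are considered here, and "the series" means these few. Any claim that something is new, unique, unknown or untested is made for them only; others in the source may bear on it.

compound 1 `Nc1nc(Cl)c2ncn(Cc3ccc(CCl)cc3)c2n1`: in a functional assay on MCF7 cells (Homo sapiens) for cytotoxicity, read by sulforhodamine B assay, with a stated time of 48 h (a lower number here means that less compound is tolerated, a higher number that more compound is tolerated), compound 1 gives only a limit, > 100000 nM.
compound 2 `ClCc1cccc(Cn2cnc3c(Cl)nc(Cl)nc32)c1`: in this assay compound 2 gives only a limit, > 100000 nM.
compound 3 `ClCc1ccc(Cn2cnc3c(Cl)nc(Cl)nc32)cc1`: in this assay compound 3 gives only a limit, > 100000 nM.

Compound 3 and compound 1 differ by one change, (amino in place of chloro on an aromatic carbon), yet the step that the two limits leave unreadable from compound 3 to compound 1 cannot be read, since (the limit of > 100000 nM in this assay, at which 3 of the 3 values shown sit). Compound 2 and compound 3 have the same atoms joined differently; the difference between the two cores is not broken down here. Compound 4 `Nc1nc(Cl)c2ncn(Cc3cccc(CCl)c3)c2n1` carries the same change relative to compound 2, (amino in place of chloro on an aromatic carbon), and the change occurs twice across the set. With the measured pair giving no readable size, the step that the limit leaves unreadable from compound 2 to compound 4 is expected to be small or unreadable in this assay. For compound 4 the estimate is 150000 nM, between 50000 nM and 500000 nM, most likely again reported as a limit.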

Compound 4, concentration lethal to 50% of the cells: 53700 nM
Compound 4: middle estimate off by 2.8-fold (0.45 log units), on the high side; the range from low to high includes it.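

In this assay, amino in place of chloro on the core of compound 2 gives an at least 1.8-fold lower number from compound 2 to compound 4 (0.27 log units; that floor lies within the scatter), so this step alone does not establish a real difference between the pair. Compound 1 gives only a limit, > 100000 nM, and this leaves the result for compound 4 neither confirmed nor contradicted. The step from compound 3 to compound 1 cannot be read, and carrying the change from one core to the other therefore remains untested: the limit of > 100000 nM in this assay, at which 3 of the 4 values shown sit.

The compounds shown leave open how a methylamino or methoxy group would read on the same aromatic carbon. From the compounds shown here alone, all four carry the chloromethyl group, and the effect of a hydroxymethyl or methyl group in its place also remains open.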